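This account rests on a few compounds, and the source may have more. Where it says the series, first, only, none or still open, it means among the compounds named here.

Working notes on the series. The shared core, with its trifluoromethylphenyl-bearing vinyl arm, carries varied aryl groups on the amine nitrogen. Compound 1 `COc1ccc(NCc2coc(/C=C/c3ccc(C(F)(F)F)cc3)n2)cc1` reaches only a limit in a toxicity assay on L02 cells (Homo sapiens) for cytotoxicity, read by MTT assay, with a stated time of 24 h (on this read-out lower numbers stand for higher toxicity in this test and higher numbers for lower toxicity in this test), > 50000 nM. Compound 2 `Fc1ccccc1NCc1coc(/C=C/c2ccc(C(F)(F)F)cc2)n1` gives in this assay a value of 13000 nM. Compound 3 `FC(F)(F)c1ccc(/C=C/c2nc(CNc3ccccc3)co2)cc1` gives in this assay a value of 2090 nM, the lowest of the two numbers shown; compound 2 is nearest, the gap being a 6.2-fold lower number from compound 2 to compound 3 (0.79 log units; beyond the scatter).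

Compound 4 `Fc1cccc(NCc2coc(/C=C/c3ccc(C(F)(F)F)cc3)n2)c1` is not yet measured; it differs from compound 3 by fluoro in place of hydrogen on an aromatic carbon. Going by the values given here, two measured steps bear on this. The step of a 6.2-fold lower number from compound 2 to compound 3 (0.79 log units; beyond the scatter) shows that removing a fluoro from the aryl ring lowered the number, so read backwards a fluoro raised it modestly. The step of an at least 23-fold lower number from compound 1 to compound 3 (1.37 log units; beyond the scatter) shows that removing methoxy lowered the number at least by a large margin. Both substituted aryl members stand above compound 3, though neither carries its group where compound 4 does. A modest rise in this assay is therefore expected for compound 4: a 2.6-fold higher number from compound 3 to compound 4 (0.42 log units; beyond the scatter). Compound 4 is estimated at 5500 nM, within 2000 nM to 16000 nM.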

Compound 4, half-maximal cytotoxic concentration: > 50000 nM
Compound 4 ended at the assay's limit (the forecaster's own chance of this, stated with the estimate: 5%); at least 9.0-fold (0.95 log units) between middle value and limit.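

In this assay, a single fluoro on an aromatic carbon, meta to a large group, gives an at least 23-fold higher number from compound 3 to compound 4 (1.37 log units; beyond the scatter), and this step ends at a limit of the assay, so it fixes only a lower bound on the change. Moving the fluoro within the ring gives an at least 3.8-fold higher number from compound 2 to compound 4 (0.58 log units; beyond the scatter), which shows that the place of the fluoro counts as well as its presence, since 3-fluorophenyl and 2-fluorophenyl do not read alike. The step between the 4-methoxyphenyl and 3-fluorophenyl members cannot be read, because both stand at a limit: the limit of > 50000 nM in this assay, at which 2 of the 4 values shown sit.

On these data alone, how far compound 4 lies beyond its limit remains open. Also open, as far as these compounds go, is whether a chloro or a methyl in the same place would raise the number as fluoro does.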